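This account rests on a few compounds, and the source may have more. Where it says the series, first, only, none or still open, it means among the compounds named here.

The measured compounds:
- compound 1 `CC/C(=C(/c1ccc(/C=C/C(=O)O)cc1)c1cc2ccccc2[nH]1)c1ccccc1`, which in a functional assay on MCF7 cells (Homo sapiens) for inhibition (a lower number here means a stronger inhibitor, a higher number a weaker inhibitor), gives 108 nM
- compound 2 `CC/C(=C(/c1ccc(/C=C/C(=O)O)cc1)c1cc2ccccc2[nH]1)c1cccc(C(F)(F)F)c1`, which in this assay gives 325 nM
- compound 3 `CC/C(=C(/c1ccc(/C=C/C(=O)O)cc1)c1cc2ccccc2[nH]1)c1cccc(Cl)c1Cl`, which in this assay gives 898 nM

Compound 3 stands at the highest number of the three in this assay; compound 2 is nearest to it and compound 1 furthest, with a 2.8-fold higher number from compound 2 to compound 3 (0.44 log units; beyond the scatter) and an 8.3-fold higher number from compound 1 to compound 3 (0.92 log units; beyond the scatter). Compound 4 `CC/C(=C(/c1ccc(/C=C/C(=O)O)cc1)c1cc2ccccc2[nH]1)c1ccc(Cl)cc1C#N` is not yet measured. It differs from compound 3 in one place: 4-chloro-2-cyanophenyl in place of 2,3-dichlorophenyl on a double-bonded chain carbon bound to a double-bonded chain carbon and a saturated chain carbon.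

Going by the values given here, two measured steps bear on this change, since each swaps one substituted phenyl at this same place for another: a 3.0-fold higher number from compound 1 to compound 2 (0.48 log units; beyond the scatter) and a 2.8-fold higher number from compound 2 to compound 3 (0.44 log units; beyond the scatter). Each exchange of the phenyl group has so far moved the number by a modest amount, and in every case a substituted phenyl has given a higher number than the bare phenyl of compound 1. Compound 4 keeps a substituted phenyl, so its number is expected to remain nearer to compound 2 and compound 3 than to compound 1, with a 1.5-fold lower number from compound 3 to compound 4 (0.18 log units; within the scatter) expected as a small move, within or only just beyond the scatter. Compound 4 is therefore estimated at 600 nM, with a range from 200 nM to 2000 nM.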

Compound 4, half-maximal inhibitory concentration: 14 nM
Compound 4: middle estimate off by 43-fold (1.63 log units), on the high side, and the stated range ends above it.
By their numbers in this assay, from the lowest: compound 4; then compound 1; then compound 2; then compound 3.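

Going by these compounds alone, until this result, each substituted phenyl at this place, on a double-bonded chain carbon bound to a double-bonded chain carbon and a saturated chain carbon, had given a higher number than the bare phenyl in this assay, but compound 4 goes against that reading (a 7.7-fold lower number from compound 1 to compound 4 (0.89 log units; beyond the scatter)). Substitution here therefore does not in itself weaken inhibition, and the choice of substituted phenyl matters far more than the earlier steps showed, since 4-chloro-2-cyanophenyl makes compound 4 the strongest inhibitor of the four (a 64-fold lower number from compound 3 to compound 4 (1.81 log units; beyond the scatter); a 23-fold lower number from compound 2 to compound 4 (1.37 log units; beyond the scatter)). Compound 3 and compound 4 both carry chlorine on this phenyl yet lie far apart, so the presence of chlorine alone does not set the number, and the entering group adds a nitrile, with one hydrogen-bond acceptor where 2,3-dichlorophenyl has none.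

No measurement given here accounts for the drop in the number. As far as these compounds go, it remains open how much of the step belongs to the nitrile and how much to the placement of the chlorine, and how a phenyl bearing only the chlorine, only the nitrile, or a carboxamide in place of the nitrile would stand.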